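Shortening a Butyl Chain on the Ring Oxygen

The source may hold more compounds than are shown below. What is called first, only, known or untested is meant among the compounds shown, and "the series" means these compounds.

Compound 1 `Oc1ccc2nc(-c3ccccc3)cc(O)c2c1` and compound 2 `Oc1cc(-c2ccccc2)nc2c(F)cccc12` carry a free hydroxyl on the shared core. In a functional assay on L1210 (1565) cells (Mus musculus) for cytotoxicity (on this read-out higher numbers stand for an effect only at larger amounts of compound and lower numbers for an effect already at smaller amounts), compound 1 gives 0.83 ug/mL, and compound 2 gives 0.57 ug/mL. Compound 3 `CCCCOc1cc(-c2ccccc2)nc2ccccc12` instead carries a butyl chain on the oxygen on the aromatic ring. For compound 3 this assay reports only a limit, > 10 ug/mL, which is where compound 3 stands (the limit of > 10 ug/mL in this assay, at which 1 of the 3 values shown sits). Compound 4 `CCCOc1cc(-c2ccccc2)nc2ccccc12` differs from compound 3 in one place: hydrogen in place of methyl on a saturated chain carbon, three bonds along the chain from an oxygen on an aromatic ring. Among the measured compounds shown here, no step between measured compounds shows what this change does. Since a chain remains on the oxygen, compound 4 is expected to stay near compound 3, with a step within the scatter, a number no higher from compound 3 to compound 4 (the limit leaves the size open). Compound 4 is estimated at 10 ug/mL, between 4 ug/mL and 30 ug/mL.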

Compound 4, half-maximal effective concentration: > 10 ug/mL
Compound 4: a limit, no number; the forecaster's own chance of this, stated with the estimate: 60%; the middle value sits exactly at the limit.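

In this assay, among the compounds shown here, compound 3 and compound 4 each give only a limit, not a number, so no step between them can be read: the limit of > 10 ug/mL in this assay, at which 2 of the 4 values shown sit. The compounds shown leave open whether going from butyl to propyl changes the result in this assay at all.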